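The source may report more compounds than this note shows. Statements on the series, on what has been measured and on what is new or still open speak of the compounds shown alone.

Compound 1 `CC(=O)Oc1ccc(/C=C/C(=O)NCCCSc2nc(-c3ccc(S(C)(=O)=O)cc3)n(-c3ccc(Br)cc3)n2)cc1OC(C)=O` and compound 2 `CC(=O)Oc1ccc(/C=C/C(=O)NCCCSc2nc(-c3ccc(S(C)(=O)=O)cc3)n(-c3ccc(F)cc3)n2)cc1OC(C)=O` share one core. In a functional assay on A549 cells (Homo sapiens) for antiproliferative activity, read by MTT assay, with a stated time of 72 h (a lower number here means a stronger inhibitor, a higher number a weaker inhibitor), compound 1 gives 23300 nM, and compound 2 gives 21800 nM. The change between them is fluoro in place of bromo on an aromatic carbon, and it made a step of a 1.1-fold lower number from compound 1 to compound 2 (0.03 log units; within the scatter). Compound 3 `COc1cc(/C=C/C(=O)OCCSc2nc(-c3ccc(S(C)(=O)=O)cc3)n(-c3ccc(Br)cc3)n2)ccc1OC(C)=O` is built on a different core; the difference between the two cores is not broken down here. In this assay compound 3 gives 11100 nM. Compound 4 `COc1cc(/C=C/C(=O)OCCSc2nc(-c3ccc(S(C)(=O)=O)cc3)n(-c3ccc(F)cc3)n2)ccc1OC(C)=O` carries the same change on the core of compound 3, namely (fluoro in place of bromo on an aromatic carbon); the place is described in the same words in both pairs, so this is the same change. The step from compound 3 to compound 4 in this assay is expected to be small, resting on a 1.1-fold lower number from compound 1 to compound 2 (0.03 log units; within the scatter), which stayed within the scatter. The expected step is a 1.1-fold lower number from compound 3 to compound 4 (0.02 log units; within the scatter). Compound 4 is estimated at 10500 nM, between 5000 nM and 22000 nM.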

Compound 4, half-maximal inhibitory concentration: 9610 nM
Beside the measured number, compound 4's estimate is 1.1-fold (0.04 log units) above it; low and high end bracket the measured number.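

In this assay, fluoro in place of bromo gives a 1.2-fold lower number from compound 3 to compound 4 (0.06 log units; within the scatter), and the change carries from one core to the other with the two steps agreeing within the scatter: the same change on two cores in this assay, a 1.1-fold lower number (0.03 log units; within the scatter) from compound 1 to compound 2 and a 1.2-fold lower number (0.06 log units; within the scatter) from compound 3 to compound 4, 1.1-fold (0.03 log units) apart, within the scatter of two such steps. This shows that on these two cores, in this one cell assay, the 4-bromophenyl to 4-fluorophenyl change leaves the number essentially unmoved. Going by these compounds alone, it does not show that the same holds on other cores or in other assays, and with both steps this small, the agreement says only that the change is without a measurable effect on both cores, not that a larger effect would carry over.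

Still open, on these data alone, is whether a different group on that aromatic carbon, such as chloro, an amine or a carboxylic acid, would move the number beyond the scatter. Also open, as far as these compounds go, is whether a longer chain to the sulfur would do so on either core.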